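The source may report more compounds than this note shows. Statements on the series, on what has been measured and on what is new or still open speak of the compounds shown alone.

Of the compounds shown here, three sharing one core have been measured in a functional assay on OE19 cells (Homo sapiens) for cytotoxicity, read by MTT assay, with a stated time of 48 h; a higher number here means a weaker inhibitor, a lower number a stronger inhibitor. Among the compounds with values here, compound 1 `CC1(C)S[C@@H]2/C(=C\C(=O)c3ccc(F)cc3)C(=O)N2[C@H]1C(=O)OC(c1ccccc1)c1ccccc1` gives 12100 nM, and compound 2 `CC1(C)S[C@@H]2/C(=C\C(=O)c3ccc(Cl)cc3)C(=O)N2[C@H]1C(=O)OC(c1ccccc1)c1ccccc1` gives 14600 nM; the only single-point step measured so far is a 1.2-fold higher number from compound 1 to compound 2 (0.08 log units; within the scatter). Compound 3 `CC1(C)S[C@@H]2/C(=C\C(=O)OC(c3ccccc3)c3ccccc3)C(=O)N2[C@H]1C(=O)OC(c1ccccc1)c1ccccc1` gives 21600 nM. Compound 2 thus stands second highest of the three numbers, within the scatter of both neighbours.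

Compound 4 `COC(=O)/C=C1/C(=O)N2[C@@H]1SC(C)(C)[C@@H]2C(=O)OC(c1ccccc1)c1ccccc1` differs from compound 2 by methoxy in place of 4-chlorophenyl on a carbonyl carbon. The measured step, swapping one halogen for another, says little about removing the whole 4-chlorophenyl; compound 3, whose carbonyl also bears an oxygen, sits within the scatter of compound 2. No step beyond the scatter is therefore expected. Compound 4 is estimated at 20000 nM, between 8000 nM and 50000 nM. That implies an expected step of a 1.4-fold higher number from compound 2 to compound 4 (0.14 log units; within the scatter).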

Compound 4, half-maximal inhibitory concentration: 20200 nM
Compound 4: the middle estimate sits 1.0-fold (0.00 log units) below what was measured; the range from low to high includes it.
By their numbers in this assay, from the lowest: compounds 1, 2, 4 and 3 (each within the scatter of the next).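

Methoxy, which has no ring, can take the place of the whole 4-chlorophenyl on the carbonyl carbon, giving a 1.4-fold higher number from compound 2 to compound 4 (0.14 log units; within the scatter); in place of 4-fluorophenyl it gives a 1.7-fold higher number from compound 1 to compound 4 (0.22 log units; within the scatter). Thus, in this assay, losing the aromatic ring here, a larger change than swapping one halogen for another, produces no step beyond the scatter. Nothing measured here offers an explanation for this result.

On these data alone, whether an amine or a carboxylic acid on this carbonyl carbon would produce a step beyond the scatter remains open. So does the effect of a longer chain in place of methoxy.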